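Compound 3 to compound 4: leaving the thiocarbonyl group

The source may hold more compounds than are shown below. What is called first, only, known or untested is meant among the compounds shown, and "the series" means these compounds.

In a functional assay on HCT-116 cells (Homo sapiens) for inhibition, read by CCK-8 assay, with a stated time of 48 h (a higher number here means a weaker inhibitor, a lower number a stronger inhibitor), compound 1 (`COc1ccc(CN(C(=O)CSC(=S)N2CCOCC2)c2cc(OC)c(OC)c(OC)c2)cc1`) gives 4130 nM, compound 2 (`COc1ccc(CN(C(=O)CSC(=S)N2CCCC2)c2cc(OC)c(OC)c(OC)c2)cc1`) gives 4970 nM and compound 3 (`COc1ccc(CN(C(=O)CSC(=S)N2CCc3ccccc32)c2cc(OC)c(OC)c(OC)c2)cc1`) gives 7710 nM. Compound 3 is not separated from the other two: a 1.9-fold higher number from compound 1 to compound 3 (0.27 log units; within the scatter) and a 1.6-fold higher number from compound 2 to compound 3 (0.19 log units; within the scatter) are both within the scatter, as is a 1.2-fold higher number from compound 1 to compound 2 (0.08 log units; within the scatter). Compound 4 (`CCN1CCN(CC(=O)N(Cc2ccc(OC)cc2)c2cc(OC)c(OC)c(OC)c2)CC1`) differs from compound 3 by a group of 8 heavy atoms (6 carbon, 2 nitrogen; one six-membered non-aromatic ring with 2 hetero atoms) in place of a group of 12 heavy atoms (9 carbon, 1 nitrogen, 2 sulfur; one five-membered non-aromatic ring with 1 hetero atom, one six-membered aromatic ring of carbon only), on a saturated chain carbon bound to a carbonyl carbon. The measured steps exchange only the group on the thiocarbonyl carbon, so none covers this change directly. They offer only a weak guide, and no step beyond the scatter is expected, though with wide uncertainty. The expected step is a 1.3-fold lower number from compound 3 to compound 4 (0.11 log units; within the scatter). For compound 4 the estimate is 6000 nM, with an expected range of 2000 nM to 20000 nM.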

Compound 4, half-maximal inhibitory concentration: > 20000 nM
Compound 4: a limit, no number (the forecaster's own chance of this, stated with the estimate: 10%); middle value at least 3.3-fold (0.52 log units) away from the limit.
By their numbers in this assay, from the lowest: compounds 1, 2 and 3 (each within the scatter of the next). At a limit, above all of these: compound 4.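

In this assay, the exchange on a saturated chain carbon bound to a carbonyl carbon gives steps beyond the scatter: an at least 2.5-fold higher number from compound 3 to compound 4 (0.41 log units; beyond the scatter), an at least 4.0-fold higher number from compound 2 to compound 4 (0.60 log units; beyond the scatter) and an at least 4.8-fold higher number from compound 1 to compound 4 (0.68 log units; beyond the scatter). Exchanges on the thiocarbonyl carbon among compound 1, compound 2 and compound 3 all stayed within the scatter, so this larger change is the first to separate compounds in the series. Compound 4 stands at a limit of the assay, not at a number: the limit of > 20000 nM in this assay, at which 1 of the 4 values shown sits.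

From the compounds shown here alone, the true size of these steps remains open. Also open is whether the thiocarbonyl group or the ring attached to it matters more, since the compounds shown change both together; a piperidin-1-yl group on the same chain carbon would be one further comparison.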